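A few compounds are considered here, and "the series" means these few. Any claim that something is new, unique, unknown or untested is made for them only; others in the source may bear on it.

Working notes on the series. Of the compounds shown here, three carry numbers so far: compound 1 `C[C@H](Nc1nc2cc(Cl)c(F)cc2s1)c1ccccc1`, compound 2 `C[C@H](CC1CCCCC1)NC(=S)Nc1ccc(F)c(Cl)c1` and compound 3 `CCCCCC[C@@H](C)Nc1nc2cc(Cl)c(F)cc2s1`. In a functional assay on HeLa cells (Homo sapiens) for cytotoxicity, read by MTT assay, with a stated time of 24 h (on this read-out lower numbers stand for stronger inhibition and higher numbers for weaker inhibition), compound 1 gives 58900 nM, compound 2 gives 45800 nM and compound 3 gives 48000 nM. Compound 1 stands at the highest of the three numbers, yet its gaps to compound 3 and to compound 2 both lie within the scatter, so the three are not separable on these data.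

Compound 4 `C[C@H](Nc1nc2cc(Cl)c(F)cc2s1)C1CCCCC1` is the next to be tested; against compound 1 the change is cyclohexyl in place of phenyl on a saturated chain carbon bound to a nitrogen on an aromatic ring and a saturated chain carbon. For the measured compounds named here, no pair of measured compounds shows this change, so nothing speaks for a step in either direction. The expectation is a step of a 1.1-fold lower number from compound 1 to compound 4 (0.03 log units; within the scatter), that is, none beyond the scatter. Compound 4 is estimated at 55000 nM, within 25000 nM to 120000 nM.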

Compound 4, half-maximal inhibitory concentration: 72500 nM
Compound 4: middle estimate off by 1.3-fold (0.12 log units), on the low side; measured number inside the range.
By their numbers in this assay, from the lowest: compounds 2, 3, 1 and 4 (each within the scatter of the next).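

In this assay, cyclohexyl in place of phenyl on a saturated chain carbon bound to a nitrogen on an aromatic ring and a saturated chain carbon gives a 1.2-fold higher number from compound 1 to compound 4 (0.09 log units; within the scatter), so the non-aromatic ring and the aromatic ring cannot be told apart here. The earlier compounds shown here gave no step at this position, and this one remains inside the scatter. No measurement bears on this result or accounts for it. Going by these compounds, whether a pyridine ring, or a cyclohexyl ring carrying an amine or a carboxylic acid, would move the number beyond the scatter stays open.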